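Acyl group exchange on the shared core, compound 2 to compound 3

A few compounds are considered here, and "the series" means these few. Any claim that something is new, unique, unknown or untested is made for them only; others in the source may bear on it.

Among the measured compounds shown here, two esters of the shared core have numbers so far. Compound 1 `O=C(CCCCCc1ccccc1)OCC1COCCOCCOCCOCCOCCO1` carries 5-phenylpentyl on the carbonyl carbon; in a functional assay on HeLa cells (Homo sapiens) for inhibition, read by sulforhodamine B assay, with a stated time of 48 h (on this read-out lower numbers stand for stronger inhibition of growth and higher numbers for weaker inhibition of growth), compound 1 gives 79000 nM. Compound 2 `CC(C)=CC1C(C(=O)OCC2COCCOCCOCCOCCOCCO2)C1(C)C` carries 2,2-dimethyl-3-(2-methylprop-1-en-1-yl)cyclopropyl in the same place, and in this assay compound 2 gives 63000 nM. The one measured step, a 1.3-fold lower number from compound 1 to compound 2 (0.10 log units; within the scatter), is within the scatter, so compound 2 and compound 1 stand level on the numbers shown and no order between them can be read.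

Compound 3 `CC/C=C/CC(=O)OCC1COCCOCCOCCOCCOCCO1` has not been measured. It differs from compound 2 by pent-2-en-1-yl in place of 2,2-dimethyl-3-(2-methylprop-1-en-1-yl)cyclopropyl on a carbonyl carbon. For the measured compounds named here, only one measured step bears on this kind of change, an exchange of the group on the carbonyl carbon: a 1.3-fold lower number from compound 1 to compound 2 (0.10 log units; within the scatter). That step stayed within the scatter, and nothing in the data points to a larger effect for the present exchange. For compound 3 no step beyond the scatter is therefore expected in this assay, in either direction. Compound 3 is estimated at 70000 nM, with a range from 30000 nM to 160000 nM. This estimate means an expected step of a 1.1-fold higher number from compound 2 to compound 3 (0.05 log units; within the scatter).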

Compound 3, concentration for 50% growth inhibition: > 100000 nM
Compound 3 ended at the assay's limit; the forecaster's own chance of this, stated with the estimate: 20%; at least 1.4-fold (0.15 log units) between middle value and limit.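

In this assay compound 3 gives > 100000 nM, which is a limit of the assay and not a number, so the size of this exchange cannot be fixed from the top end: the limit of > 100000 nM in this assay, at which 1 of the 3 values shown sits.

Pent-2-en-1-yl on the carbonyl carbon gives an at least 1.5-fold higher number from compound 2 to compound 3 (0.20 log units; that floor lies within the scatter), and the listed step from the other ester gives an at least 1.2-fold higher number from compound 1 to compound 3 (0.10 log units; that floor lies within the scatter). Both figures are floors, so the true steps could be larger or could stay within the scatter, and no order among the three esters can be read. What is new is only that this place can carry a group, here without a ring and with the smaller count of carbon atoms, that takes the value to the limit of the read-out, whereas the two earlier groups, one with a phenyl ring and one with a three-membered ring, both gave numbers.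

On these data alone, it stays open whether any group on this carbonyl carbon moves the number down by a step beyond the scatter, for instance a chain ending in an amine or a carboxylic acid. As far as these compounds go, it also stays open whether a saturated pentyl chain would differ from pent-2-en-1-yl, or whether a longer unbranched chain would return a number below the limit.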